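Ethyl on the carbamoyl nitrogen in two cores

This account rests on a few compounds, and the source may have more. Where it says the series, first, only, none or still open, it means among the compounds named here.

Two cores carry the same piperazine dithiocarbamate arm and differ in the benzyl group on the triazole. Compound 1 `NC(=O)N1CCN(C(=S)SCc2cn(Cc3ccccc3F)nn2)CC1` and compound 3 `COc1cc(Cn2cc(CSC(=S)N3CCN(C(N)=O)CC3)nn2)cc(OC)c1OC` both bear an unsubstituted carbamoyl; how the two cores differ is not broken down here. In a functional assay on MCF7 cells (Homo sapiens) for cytotoxicity, read by MTT assay, with a stated time of 72 h (on this read-out lower numbers stand for stronger inhibition and higher numbers for weaker inhibition), compound 1 gives only a limit, > 128000 nM. Compound 3 likewise reaches only a limit in this assay, > 128000 nM. Indeed two of the three measured values sit at the limit of > 128000 nM in this assay, at which 2 of the 3 values shown sit.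

Compound 2 `CCNC(=O)N1CCN(C(=S)SCc2cn(Cc3ccccc3F)nn2)CC1` carries ethyl in place of hydrogen on an amide-type nitrogen on the core of compound 1. In this assay compound 2 gives 5760 nM. The step is an at least 22-fold lower number from compound 1 to compound 2 (1.34 log units; beyond the scatter), and it starts from a limit, so its true size is not fixed.

Compound 4 `CCNC(=O)N1CCN(C(=S)SCc2cn(Cc3cc(OC)c(OC)c(OC)c3)nn2)CC1` makes the same change on the core of compound 3: ethyl in place of hydrogen on an amide-type nitrogen. The place is worded the same in both pairs, an amide-type nitrogen whose other neighbours are a carbonyl carbon, so this is the same change rather than merely the same kind. Among the measured compounds shown here, since compound 3 stands at a limit in this assay, only a lower bound on its value is known, and the step for compound 4 is expected to be at most as large as the one seen for compound 2, estimated as an at least 10-fold lower number from compound 3 to compound 4 (1.02 log units; beyond the scatter). With only one such step shown, and that one open-ended, the expectation for compound 4 in this assay is 12000 nM, spanning 3000 nM to 60000 nM.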

Compound 4, half-maximal inhibitory concentration: > 128000 nM
Compound 4: only a limit was reported; the forecaster's own chance of this, stated with the estimate: 25%; middle value at least 10-fold (1.02 log units) away from the limit.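

Compound 3 and compound 4 both give only a limit in this assay, so no step can be read between them, and the ethyl change on this core has no readable size; the one value that applies to both is this: the limit of > 128000 nM in this assay, at which 3 of the 4 values shown sit.

The compounds shown leave open whether ethyl in place of hydrogen on the amide-type nitrogen changes the read-out at all on the core of compound 3.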